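A few compounds are considered here, and "the series" means these few. Any claim that something is new, unique, unknown or untested is made for them only; others in the source may bear on it.

Of the compounds shown here, two of a shared amide series have been measured in a physicochemical assay for solubility, at pH 7.4; a higher number here means a more soluble compound, a lower number a less soluble compound. Compound 1, `Cc1cc(Cl)c(-c2cn(C)c(C)n2)cc1NC(=O)c1ccc(OCc2ccccn2)cc1`, gives only a limit in this assay, a reading of < 1000 nM. Compound 2, `Cc1cc(C)c(-c2nc3ccccc3[nH]2)cc1NC(=O)c1ccc(OCc2ccccn2)cc1`, likewise gives only a limit in this assay, a reading of < 1000 nM. Both readings thus sit at the same floor of the assay, as recorded by the limit of < 1000 nM in this assay, at which 2 of the 2 values shown sit, and neither is a number; nothing can be said about the order of compound 1 and compound 2.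

Compound 3, `Cc1cc(C)c(-c2c[nH]nc2C)cc1NC(=O)c1ccc(OCc2ccccn2)cc1`, has not yet been measured in this assay. It differs from compound 2 in one place: 3-methyl-1H-pyrazol-4-yl in place of 1H-benzimidazol-2-yl on an aromatic carbon. Going by the values given here, no measured step between any two compounds of this set is available, so no measured guide to the size of this change exists. Compound 3 is expected to remain near the same floor, with the step from compound 2 to compound 3 estimated at a step that the limit leaves unreadable from compound 2 to compound 3. Compound 3 is estimated to give 600 nM, in a range of 100 nM to 3000 nM, quite possibly again as a limit.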

Compound 3, solubility: 33000 nM
The estimate for compound 3 lay 55-fold (1.74 log units) below the measured number, outside the stated range (above it).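

In this assay, going by these compounds alone, 3-methyl-1H-pyrazol-4-yl in place of 1H-benzimidazol-2-yl gives an at least 33-fold higher number from compound 2 to compound 3 (1.51 log units; beyond the scatter), the first step in the set that can be read and the first reading that is a number rather than a limit. It shows that the group on this aromatic carbon, ortho to a methyl group and para to a methyl group, can move the read-out well beyond the scatter. The true size of the step stays unknown, since compound 2 gives only a limit: the limit of < 1000 nM in this assay, at which 2 of the 3 values shown sit.

The compounds shown do not separate the loss of the six-membered aromatic ring from the change of five-membered ring or the added methyl group. From the compounds shown here alone, it also remains open how a 1H-pyrazol-4-yl group without the methyl, or a pyrazole carrying an amine, would read at this position.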